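A few compounds are considered here, and "the series" means these few. Any claim that something is new, unique, unknown or untested is made for them only; others in the source may bear on it.

Measured compounds:
- Compound 1, `CCn1cc(C(CC)(CC)c2ccc(OCC(C)O)c(C)c2)cc1C(=O)NC(O)CO`: 81.6 nM
- Compound 2, `CCN(CC)CCCNC(=O)c1ccc(C(CC)(CC)c2ccc(OCCC(C)(C)O)c(C)c2)n1CC`: 92.5 nM

Both compounds were tested in an assay on isolated protein for binding affinity to vitamin D3 receptor (Homo sapiens), read by fluorescence polarization; on this read-out higher numbers stand for weaker inhibition and lower numbers for stronger inhibition. Compound 1 shows the lower of the two numbers, yet the gap to compound 2 is within the scatter of repeated measurements, so the two read as equal. Among the measured compounds shown here, the two compounds differ in several places at once, so no single step can be drawn between them.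

Compound 3, `CCn1cc(C(CC)(CC)c2ccc(OCC(C)O)c(C)c2)cc1C(=O)NCCN1CCN(C)CC1`, has not yet been measured. It differs from compound 1 in one place only: 2-(4-methylpiperazin-1-yl)ethyl in place of 1,2-dihydroxyethyl on an amide-type nitrogen. The group that leaves carries two hydroxyl groups; the group that enters carries a six-membered ring with two nitrogen atoms and no hydrogen-bond donors. For the measured compounds named here, no measured pair shows this exact exchange. Going by the values given here, the only related hint is compound 2, whose amide also ends in a chain with a basic nitrogen and which gives 92.5 nM in this assay, close to compound 1. The expectation is therefore a step of a 1.1-fold higher number from compound 1 to compound 3 (0.04 log units; within the scatter), not clearly beyond the scatter in either direction. Compound 3 is estimated at 90 nM, with a range from 40 nM to 220 nM.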

Compound 3, half-maximal inhibitory concentration: 57.2 nM
For compound 3 the middle estimate is 1.6-fold (0.20 log units) above the measured one, and the stated range covers the measured number.
By their numbers in this assay, from the lowest: compounds 3, 1 and 2 (each within the scatter of the next).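

In this assay, the exchange of 1,2-dihydroxyethyl for 2-(4-methylpiperazin-1-yl)ethyl on the amide-type nitrogen gives a 1.4-fold lower number from compound 1 to compound 3 (0.15 log units; within the scatter) and so the two compounds read as equal. Among the compounds shown here, this is the first comparison in which only one place differs, and it shows that this position accepts a much larger group, going from 4 to 9 heavy atoms and adding a six-membered ring, while the hydrogen-bond donors of the leaving group drop from 2 to 0 with no change beyond the scatter. The data shown hold no measurement that explains why the two groups read alike.

As far as these compounds go, with one exchange at this position, it remains open whether the piperazine ring, its nitrogen atoms or simply the length of the chain matters, and a 2-(morpholin-4-yl)ethyl group, a plain ethyl group or a chain ending in a carboxylic acid on the same nitrogen would help to separate these parts. From the compounds shown here alone, it is also open whether the same exchange would read alike on the core of compound 2, where the amide sits in a different place and the ether chain differs.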